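This account rests on a few compounds, and the source may have more. Where it says the series, first, only, none or still open, it means among the compounds named here.

Working notes on the series. Compound 1 `Cc1cc(C)n2nccc2n1` is the parent; in a functional assay on the whole organism with Rattus norvegicus as the target (a lower number here means that less compound is needed, a higher number that more compound is needed for the effect), compound 1 gives 40 mg/kg. Compound 2 `Cc1cc(C)n2ncc(F)c2n1` carries fluoro on an aromatic carbon; in this assay compound 2 gives 40 mg/kg. The single measured step, no change at the digits printed from compound 1 to compound 2 (within the scatter), is flat, so compound 2 stands level with compound 1 at the digits shown, and the series so far has no spread in this assay at all.

Compound 3 `Cc1cc(C)n2ncc(Cl)c2n1` is not yet measured. Against compound 2 the change is chloro in place of fluoro on an aromatic carbon.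

Within the data shown here, the only measured step that bears on this is the replacement of hydrogen by fluoro on an aromatic carbon, no change at the digits printed from compound 1 to compound 2 (within the scatter), which stayed within the scatter. Nothing measured speaks directly to chloro. Because no change at the digits printed from compound 1 to compound 2 (within the scatter) showed no shift, the expectation for compound 3 in this assay is a step of about no change at the digits printed from compound 2 to compound 3 (within the scatter), nothing beyond the scatter and in no particular direction. For compound 3 the estimated minimum effective dose in this assay is 40 mg/kg, with an expected range from 20 mg/kg to 80 mg/kg.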

Compound 3, minimum effective dose: 10 mg/kg
The estimate for compound 3 lay 4.0-fold (0.60 log units) above the measured number, outside the stated range (below it).
By their numbers in this assay, from the lowest: compound 3; then compounds 1 and 2 (each within the scatter of the next).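

This position, on the five-membered aromatic ring with 2 nitrogen, is not indifferent to the group it carries in this assay: chloro in place of fluoro gives a 4.0-fold lower number from compound 2 to compound 3 (0.60 log units; beyond the scatter) and so shows that the flat fluoro step did not describe the position as a whole. Measured against the parent, chloro in place of hydrogen gives a 4.0-fold lower number from compound 1 to compound 3 (0.60 log units; beyond the scatter) in the same assay, and compound 3 therefore stands apart from both earlier compounds, which remain level with each other. No measurement of any property of these groups is available to account for the difference between chloro and fluoro at this position.

With only hydrogen, fluoro and chloro shown here, it remains open whether the lower number is particular to chloro or extends to other groups at this position, such as bromo, methyl or an amine. From the compounds shown here alone, the methyl groups of the shared core are the same in all three compounds, so it is also open whether the chloro step would hold with a longer chain in place of either one.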